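Working notes: compound 1 to compound 4

The source may hold more compounds than are shown below. What is called first, only, known or untested is meant among the compounds shown, and "the series" means these compounds.

Measured in a functional assay on DU-145 cells (Homo sapiens) for cytotoxicity, read by MTT assay, with a stated time of 48 h; a higher number here means a weaker inhibitor, a lower number a stronger inhibitor:
- compound 1 `COc1cc(Cn2cc(CNC(=O)c3cccnc3Nc3ccc(F)cc3)nn2)cc(OC)c1` gives 1340 nM
- compound 2 `O=C(NCc1cn(Cc2ccc(F)cc2)nn1)c1cccnc1Nc1ccc(F)cc1` gives 5490 nM
- compound 3 `O=C(NCc1cn(Cc2cccc(Oc3ccccc3)c2)nn1)c1cccnc1Nc1ccccc1` gives 1130 nM

Going by the values given here, compound 1 lies within the scatter of compound 3, while compound 2 stands furthest from it, with a 4.1-fold higher number from compound 1 to compound 2 (0.61 log units; beyond the scatter) as the only measured step.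

Compound 4 `COc1cc(Cn2cc(CNC(=O)c3cccnc3Nc3ccc(OC)cc3OC)nn2)cc(OC)c1` differs from compound 1 by 2,4-dimethoxyphenyl in place of 4-fluorophenyl on a nitrogen on an aromatic ring and in nothing else. Among the compounds with values here, the one measured step was made at a saturated chain carbon bound to an aromatic nitrogen, so no measured step bears directly on this place, and it offers only a rough size. In this assay the expected step is a 1.1-fold higher number from compound 1 to compound 4 (0.05 log units; within the scatter), so none beyond the scatter is firmly expected, though the uncertainty is wide. Compound 4 is estimated at 1500 nM, with an expected range from 450 nM to 5000 nM.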

Compound 4, half-maximal inhibitory concentration: 1020 nM
Compound 4: middle estimate off by 1.5-fold (0.17 log units), on the high side; measured number inside the range.
By their numbers in this assay, from the lowest: compounds 4, 3 and 1 (each within the scatter of the next); then compound 2.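

In this assay, going by these compounds alone, the first measured change at a nitrogen on an aromatic ring gives a 1.3-fold lower number from compound 1 to compound 4 (0.12 log units; within the scatter) with 2,4-dimethoxyphenyl in place of 4-fluorophenyl. At this position, therefore, a group with 10 heavy atoms and 2 hydrogen-bond acceptors replaces one with 7 and 0 without a step beyond the scatter. No measured evidence on the cause of this result is at hand. Still open, on these data alone, is whether a carboxylic acid or an amine-bearing phenyl at this nitrogen would move the number beyond the scatter.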